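The compounds below may be only part of what the source reports. "The series", "measured", "known", "first", "only" and "open" are said of these compounds alone.

Measured compounds:
Compound 1, `CCC(=O)Nc1ccc(Nc2cccc(OC)c2)cc1`: in an assay on isolated protein for binding affinity to melatonin receptor type 1A (Homo sapiens) (on this read-out higher numbers stand for weaker inhibition and lower numbers for stronger inhibition), compound 1 gives 61 nM.
Compound 2, `CCCC(=O)Nc1ccc(Nc2cccc3c2CCO3)cc1`: this assay reports only a limit for compound 2, which gives > 500 nM.

The account turns on compound 2. Where compound 2 stands in this assay is known only as a limit, as the limit of > 500 nM in this assay, at which 1 of the 2 values shown sits, records, so compound 1 is the only one of the pair with a number. Within the data shown here, no step between measured compounds is available, as compound 1 and compound 2 differ in more than one place, and their two values can only be read side by side. Compound 3, `CCCC(=O)Nc1ccc(N(C)c2cccc3c2CCO3)cc1`, differs from compound 2 in a single respect: methyl in place of hydrogen on a nitrogen on an aromatic ring. Without a measured step of this kind to lean on, the step in this assay is expected to be a step that the limit leaves unreadable from compound 2 to compound 3, a small shift, if any, with binding likely staying weak. Compound 3 is therefore expected to give about 1000 nM in this assay, with a range from 300 nM to 5000 nM.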

Compound 3, inhibition constant: 36 nM
For compound 3 the middle estimate is 28-fold (1.44 log units) above the measured one, outside the stated range (below it).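

In this assay, compound 2 is recorded only as a limit, > 500 nM. Methyl in place of hydrogen on a nitrogen on an aromatic ring, the only change in this pair, gives an at least 13-fold lower number from compound 2 to compound 3 (1.14 log units; beyond the scatter), so for this pair the hydrogen on that nitrogen is not needed for a measured affinity, and this position accepts a methyl group with a gain that lies beyond the scatter. The true size of the step stays open on one side, and its printed size is only a bound: the limit of > 500 nM in this assay, at which 1 of the 3 values shown sits.

As far as these compounds go, compound 1 also carries a hydrogen on the corresponding nitrogen but differs from compound 3 in more than one place, so whether methyl has a similar effect on the core of compound 1, with its methoxy group and shorter acyl chain, remains open. With only hydrogen and methyl shown on this nitrogen, it is also open whether an ethyl group, a longer chain or an acetyl group would be accepted there, and how the number in this assay would then move.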